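The source may hold more compounds than are shown below. What is called first, only, known or untested is meant among the compounds shown, and "the series" means these compounds.

Three analogues of the shared core have been run in a functional assay on HeLa cells (Homo sapiens) for cytotoxicity, read by MTT assay, with a stated time of 72 h; on this read-out higher numbers stand for weaker inhibition and lower numbers for stronger inhibition. Compound 1 `O=C1c2cccc([N+](=O)[O-])c2NC[C@@]12[C@H](c1ccc(F)cc1)[C@@H](c1ccccc1)N[C@]21C(=O)Nc2ccc(Cl)cc21` gives 27000 nM in this assay. Compound 2 `O=C1c2cccc([N+](=O)[O-])c2NC[C@@]12[C@H](c1ccc(Cl)cc1)[C@@H](c1ccccc1)N[C@]21C(=O)Nc2ccc(Br)cc21` gives 23000 nM. Compound 3 `O=C1c2cccc([N+](=O)[O-])c2NC[C@@]12[C@H](c1ccc(Br)cc1)[C@@H](c1ccccc1)N[C@]21C(=O)Nc2ccc(Br)cc21` gives 25000 nM. Going by the values given here, the one single-point step measured so far, a 1.1-fold higher number from compound 2 to compound 3 (0.04 log units; within the scatter), places bromo where chloro stood on an aromatic carbon and does not move the number beyond the scatter. Compound 3 stands second highest of the three numbers, with compound 1 nearest and compound 2 furthest, all within the scatter of one another, so no ranking of the three can be drawn from these data.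

Compound 4 `O=C1c2cccc([N+](=O)[O-])c2NC[C@@]12[C@H](c1ccc(F)cc1)[C@@H](c1ccccc1)N[C@]21C(=O)Nc2ccc(Br)cc21` is not yet measured. It differs from compound 3 by fluoro in place of bromo on an aromatic carbon. The 4-fluorophenyl that enters here is already present in compound 1, whose 27000 nM lies with the other two. Among the compounds with values here, the only measured step of a related kind, a 1.1-fold higher number from compound 2 to compound 3 (0.04 log units; within the scatter), stayed within the scatter. No shift beyond the scatter is therefore expected in this assay. For compound 4 the expected step is a 1.0-fold higher number from compound 3 to compound 4 (0.02 log units; within the scatter). Compound 4 is estimated at 26000 nM, within 13000 nM to 52000 nM.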

Compound 4, half-maximal inhibitory concentration: 26000 nM
The estimate for compound 4 equals the measured number at the digits printed; the range from low to high includes it.
By their numbers in this assay, from the lowest: compounds 2, 3, 4 and 1 (each within the scatter of the next).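

In this assay, the 4-bromophenyl to 4-fluorophenyl change gives a 1.0-fold higher number from compound 3 to compound 4 (0.02 log units; within the scatter), and fluoro in place of chloro on this aromatic carbon gives a 1.1-fold higher number from compound 2 to compound 4 (0.05 log units; within the scatter), so fluoro, chloro and bromo have now all been read at this place with the rest of the molecule unchanged, and none separates from the others. At the other halogen position, bromo in place of chloro gives a 1.0-fold lower number from compound 1 to compound 4 (0.02 log units; within the scatter). Bromo in place of chloro can now be read on two cores, and the two readings do not part: the same change on two cores in this assay, a 1.1-fold higher number (0.04 log units; within the scatter) from compound 2 to compound 3 and a 1.0-fold lower number (0.02 log units; within the scatter) from compound 1 to compound 4, 1.1-fold (0.05 log units) apart, within the scatter of two such steps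

The compounds shown carry only halogens at this place, so it remains open whether an amine, a carboxylic acid or a longer chain there would move the number beyond the scatter. On these data alone, whether an amine at the other halogen position would do so is also open.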